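Swapping methoxy for methyl on the aryl ring of a pyrazole series

The source may hold more compounds than are shown below. What is called first, only, known or untested is meant among the compounds shown, and "the series" means these compounds.

Measured compounds:
compound 1, `COc1ccc(-c2nn(-c3ccccc3)cc2CNc2ccc(F)cc2)cc1`, 5980 nM
compound 2, `COc1ccc(-c2nn(-c3ccccc3)cc2CNc2ccc(C)cc2)cc1`, 8160 nM
compound 3, `COc1ccc(-c2nn(-c3ccccc3)cc2CNc2ccc(Cl)cc2)cc1`, 6250 nM

All three were tested in a functional assay on MCF7 cells (Homo sapiens) for antiproliferative activity, read by MTT assay, with a stated time of 48 h; a lower number here means a stronger inhibitor, a higher number a weaker inhibitor. Compound 1 gives the lowest of the three numbers, but the other two sit close by: the step of a 1.0-fold higher number from compound 1 to compound 3 (0.02 log units; within the scatter) and the step of a 1.4-fold higher number from compound 1 to compound 2 (0.13 log units; within the scatter) are both within the scatter of repeat measurements, as is the step of a 1.3-fold lower number from compound 2 to compound 3 (0.12 log units; within the scatter). Since these three compounds cannot be told apart, none of them can be called the most or least potent.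

Compound 4, `Cc1ccc(-c2nn(-c3ccccc3)cc2CNc2ccc(F)cc2)cc1`, is not yet measured. It differs from compound 1 in this way: methyl in place of methoxy on an aromatic carbon. Going by the values given here, this change sits on the 4-methoxyphenyl group, whereas every measured step concerns a different ring, so no measured step bears directly on it. What the measured steps do show is that single small changes on an aromatic carbon in this series have so far moved the number by less than the scatter. On that basis, the step of a 1.1-fold higher number from compound 1 to compound 4 (0.04 log units; within the scatter) is expected to fall within the scatter rather than beyond it. Compound 4 is therefore estimated at 6500 nM, with a range from 3000 nM to 14000 nM.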

Compound 4, half-maximal inhibitory concentration: 5880 nM
Compound 4: the middle estimate sits 1.1-fold (0.04 log units) above what was measured; measured number inside the range.
By their numbers in this assay, from the lowest: compounds 4, 1, 3 and 2 (each within the scatter of the next).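

In this assay, the step of a 1.0-fold lower number from compound 1 to compound 4 (0.01 log units; within the scatter) is the only measured step among the compounds shown that touches the 4-methoxyphenyl group, and it stays within the scatter. Going to 4-methylphenyl takes away the oxygen, and with it the one hydrogen-bond acceptor counted for methoxy, yet compound 1 and compound 4 still cannot be told apart in this cell test, so for this one pair the oxygen is not needed to keep the number in the same range. No evidence is available on why the two compounds read alike here.

From the compounds shown here alone, one small swap cannot show how much change this position accepts, so it stays open whether a hydroxyl, an amine, a carboxylic acid or a longer chain such as butoxy in the same place would also leave the number within the scatter. Going by these compounds, it is also open whether methyl in place of methoxy reads the same way when the fluoro group on the other ring is replaced by chloro or methyl, as in compound 3 and compound 2.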